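A few compounds are considered here, and "the series" means these few. Any claim that something is new, unique, unknown or untested is made for them only; others in the source may bear on it.

Measured so far:
- compound 1, `O=C1O/C(=C\Cn2cc(-c3cc(C(F)(F)F)cc(C(F)(F)F)c3)nn2)C(OCc2ccccc2)=C1OCc1ccccc1`: > 100000 nM
- compound 2, `O=C1O[C@H]([C@@H](O)Cn2cc(CNS(=O)(=O)c3ccc(F)cc3)nn2)C(OCc2ccccc2)=C1OCc1ccccc1`: 18300 nM
- compound 3, `O=C1O/C(=C\Cn2cc(-c3cccc(O)c3)nn2)C(OCc2ccccc2)=C1OCc1ccccc1`: 61700 nM

All three were tested in a functional assay on HepG2 cells (Homo sapiens) for antiproliferative activity, read by MTT assay, with a stated time of 72 h; a higher number here means a weaker inhibitor, a lower number a stronger inhibitor. For compound 1 the reading > 100000 nM is a limit of the assay, not a number. Of the two numbers that remain, compound 2 gives the lower one, and compound 3 at 61700 nM stands clearly beyond the usual scatter from it. Compound 4, `O=C1O[C@H]([C@@H](O)Cn2cc(CCO)nn2)C(OCc2ccccc2)=C1OCc1ccccc1`, is not yet measured; it differs from compound 2 in one place.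

hydroxymethyl in place of ((4-fluorophenyl)sulfonyl)amino on a saturated chain carbon bound to an aromatic carbon

No measured pair among these compounds shows what such a change does, so the expectation rests on compound 2 alone. The change is expected to weaken inhibition, by an estimated 2.7-fold higher number from compound 2 to compound 4 (0.44 log units; beyond the scatter). Compound 4 is therefore expected to give about 50000 nM, with a likely range from 15000 nM to 150000 nM.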

Compound 4, half-maximal inhibitory concentration: 68100 nM
Beside the measured number, compound 4's estimate is 1.4-fold (0.13 log units) below it; the range from low to high includes it.
By their numbers in this assay, from the lowest: compound 2; then compounds 3 and 4 (each within the scatter of the next). At a limit, above all of these: compound 1.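

In this assay, putting hydroxymethyl in place of ((4-fluorophenyl)sulfonyl)amino gives a 3.7-fold higher number from compound 2 to compound 4 (0.57 log units; beyond the scatter), the first effect of a single change that can be read in this series. The step is modest, and compound 4 still gives a measured number without that aromatic ring. Compound 1 stands at a limit of the assay, not at a number: the limit of > 100000 nM in this assay, at which 1 of the 4 values shown sits.

Going by these compounds, this one change removes the fluorine, the aromatic ring and the sulfonyl group together, and which of them matters remains open. Also open, on these data alone, is how an amine, a carboxylic acid or a longer chain would read at this place.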